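Replacing (piperidin-1-yl)sulfonyl with (3-fluorophenyl)carbamoyl

A few compounds are considered here, and "the series" means these few. Any claim that something is new, unique, unknown or untested is made for them only; others in the source may bear on it.

For the measured compounds named here, compound 2 `CN1CCN(c2ccc(-c3cc4c(N5CCN(S(=O)(=O)N6CCCCC6)CC5)ncnc4s3)cc2)CC1` gives 8130 nM in a functional assay on MDA-MB-231 cells (Homo sapiens) for antiproliferative activity, read by MTT assay, with a stated time of 48 h (on this read-out higher numbers stand for weaker inhibition and lower numbers for stronger inhibition), the higher of the two numbers so far; compound 1 `C=CS(=O)(=O)N1CCN(c2nc(OC[C@H]3CCCN3C)nc3sc(-c4ccc(N5CCN(C)CC5)cc4)cc23)[C@@H](C)C1` gives 2880 nM in this assay, and the gap between them lies beyond the scatter. Compound 3 `CN1CCN(c2ccc(-c3cc4c(N5CCN(C(=O)Nc6cccc(F)c6)CC5)ncnc4s3)cc2)CC1` is not yet measured; it differs from compound 2 by (3-fluorophenyl)carbamoyl in place of (piperidin-1-yl)sulfonyl on an amine nitrogen in a ring. Going by the values given here, no step between measured compounds covers this change, so the direction rests on nothing firmer than the single number for compound 2. For compound 3 a moderate fall in the number is expected, a 2.0-fold lower number from compound 2 to compound 3 (0.31 log units; beyond the scatter), though a result within the scatter of compound 2 would not surprise. Compound 3 is estimated at 4000 nM, within 1000 nM to 16000 nM.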

Compound 3, half-maximal inhibitory concentration: 13200 nM
Compound 3: middle estimate off by 3.3-fold (0.52 log units), on the low side; low and high end bracket the measured number.
By their numbers in this assay, from the lowest: compound 1; then compounds 2 and 3 (each within the scatter of the next).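

In this assay the step is a 1.6-fold higher number from compound 2 to compound 3 (0.21 log units; within the scatter) for (3-fluorophenyl)carbamoyl in place of (piperidin-1-yl)sulfonyl on an amine nitrogen in a ring. At this position, then, a carbamoyl carrying an aromatic ring and a sulfonyl carrying a non-aromatic ring are not told apart by this read-out. No supporting measurement bears on this result.

Still open, from the compounds shown here alone, is whether an acetyl group or a bare ring amine at this nitrogen would move the number beyond the scatter.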